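From a Bare Phenol to Its Hydroxymethyl Analogue

This account rests on a few compounds, and the source may have more. Where it says the series, first, only, none or still open, it means among the compounds named here.

Compound 1 `CC(C)=CCC[C@H](C)c1ccc(C)cc1O`, in a functional assay on MDA-MB-231 cells (Homo sapiens) for inhibition, read by MTT assay, with a stated time of 72 h (a higher number here means a weaker inhibitor, a lower number a stronger inhibitor), compound 1 gives > 50000 nM.
Compound 2 `CCOC(CCN1COc2c([C@@H](C)CCC=C(C)C)ccc(C)c2C1)OCC`, in this assay compound 2 gives 11300 nM.

The value recorded for compound 1 is a limit of the assay, not a number; compound 1 sits at the limit of > 50000 nM in this assay, at which 1 of the 2 values shown sits. Compound 2 gives a measured figure, and the pair share no single-point change. Compound 3 `CC(C)=CCC[C@H](C)c1ccc(C)c(CO)c1O` differs from compound 1 by hydroxymethyl in place of hydrogen on an aromatic carbon. For the measured compounds named here, with no measured step of this kind to lean on, the expected step of an at least 1.2-fold lower number from compound 1 to compound 3 (0.09 log units; that floor lies within the scatter) is small and, if anything, toward stronger inhibition. Compound 3 is therefore estimated at 40000 nM, within 10000 nM to 100000 nM.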

Compound 3, half-maximal inhibitory concentration: 22200 nM
Compound 3: the middle estimate sits 1.8-fold (0.26 log units) above what was measured; the measured number falls inside the stated range.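

In this assay, hydroxymethyl in place of hydrogen, on the aromatic carbon ortho to a hydroxy group and ortho to a methyl group, brings an at least 2.2-fold lower number from compound 1 to compound 3 (0.35 log units; beyond the scatter). This gives the position its first step that can be read, and it runs toward stronger inhibition. The step is a floor only, because the value of compound 1 is a limit of the assay and not a number: the limit of > 50000 nM in this assay, at which 1 of the 3 values shown sits.

The compounds shown leave open whether the oxygen of the new group or its carbon carries the step. They also leave open how a methyl, an aminomethyl or a carboxylic acid on this carbon would compare.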